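Three Limits and an Untested 2-Aminophenyl Analogue

The compounds below may be only part of what the source reports. "The series", "measured", "known", "first", "only" and "open" are said of these compounds alone.

Half-maximal cytotoxic concentrations in a functional assay on HEK293 cells (Homo sapiens) for cytotoxicity (on this read-out higher numbers stand for lower toxicity in this test and lower numbers for higher toxicity in this test), for the measured compounds, each value a limit:
- Compound 1 `COc1ccc([C@H]2CC(=O)N(C(C)=O)C2)cc1OC1CCCC1` gives > 10000 nM as a limit
- Compound 2 `COc1ccc([C@H]2CC(=O)N(c3ccccc3)C2)cc1OC1CCCC1` gives > 10000 nM as a limit
- Compound 3 `COc1ccc([C@H]2CC(=O)N(c3cccc(O)c3)C2)cc1OC1CCCC1` gives > 10000 nM as a limit

Compound 3 therefore has no number of its own, only a limit shared with the other two compounds, as shown by the limit of > 10000 nM in this assay, at which 3 of the 3 values shown sit, and nothing more precise. Compound 4 `COc1ccc([C@H]2CC(=O)N(c3ccccc3N)C2)cc1OC1CCCC1` has 2-aminophenyl in place of 3-hydroxyphenyl on an amide-type nitrogen in a ring, the change recorded as 2-aminophenyl in place of 3-hydroxyphenyl on an amide-type nitrogen in a ring and made on a five-membered non-aromatic ring with 1 nitrogen.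

For the measured compounds named here, three measured steps bear on this change. They are a step that the two limits leave unreadable from compound 1 to compound 2 and a step that the two limits leave unreadable from compound 1 to compound 3 and a step that the two limits leave unreadable from compound 2 to compound 3 and none of them gives a size. The replacement of the aromatic group at this nitrogen has so far not moved any compound away from the limit, so no step beyond the usual scatter is expected in this assay for this change. The expected step is a step that the limit leaves unreadable from compound 3 to compound 4 and it carries little certainty. For compound 4 the estimated value is 20000 nM with an expected range from 8000 nM to 50000 nM and a report as a limit is the likeliest outcome.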

Compound 4, half-maximal cytotoxic concentration: > 10000 nM
Compound 4: only a limit was reported; the forecaster's own chance of this, stated with the estimate: 85%; the middle value is on the limit's open side.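

In this assay compound 4 gives > 10000 nM, which is a limit. Its steps from compound 1, compound 2 and compound 3 cannot be read, as all the compounds share one limit: the limit of > 10000 nM in this assay, at which 4 of the 4 values shown sit. The compounds shown leave open how far each lies from that limit and whether any group on the amide-type nitrogen changes the read-out.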